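Phenyl on the chain of compound 2

The source may hold more compounds than are shown below. What is called first, only, known or untested is meant among the compounds shown, and "the series" means these compounds.

Compound 2 `CCCCNc1nc(N)nc(C)c1CC` gives 1660 nM in an assay on HEK293 cells for agonist activity at Toll-like receptor 8 (Homo sapiens), read by spectrophotometry (on this read-out higher numbers stand for an effect only at larger amounts of compound and lower numbers for an effect already at smaller amounts), and stands at the lowest number of the three measured compounds. Compound 1 `C#Cc1c(C)nc(N)nc1NCCCC` gives 4900 nM and compound 3 `CCCCNc1nc(N)nc(C)c1C#C[Si](C)(C)C` gives 9240 nM. The steps among them run as follows: a 3.0-fold lower number from compound 1 to compound 2 (0.47 log units; beyond the scatter); a 5.6-fold higher number from compound 2 to compound 3 (0.75 log units; beyond the scatter); a 1.9-fold higher number from compound 1 to compound 3 (0.28 log units; within the scatter). Both steps that add heavy atoms on or beyond the aromatic carbon end in a higher number, the one beyond the scatter being the larger addition.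

Compound 4 `CCCCNc1nc(N)nc(C)c1CCc1ccccc1` differs from compound 2 by phenyl in place of hydrogen on a saturated chain carbon, two bonds along the chain from an aromatic carbon. This again adds a group on the substituent carried by the aromatic carbon, so the bearing steps are the two additions above: a 5.6-fold higher number from compound 2 to compound 3 (0.75 log units; beyond the scatter) is the closer parallel, as a sizeable group enters on the aromatic carbon, while a 1.9-fold higher number from compound 1 to compound 3 (0.28 log units; within the scatter) shows a smaller rise when atoms are added further out. A rise in the number is therefore expected, of a size between those two steps. The estimate for compound 4 is 5000 nM, with a range from 1500 nM to 16000 nM. In step terms, a 3.0-fold higher number from compound 2 to compound 4 (0.48 log units; beyond the scatter) is the expected outcome.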

Compound 4, half-maximal effective concentration: 1190 nM
Compound 4: the middle estimate sits 4.2-fold (0.62 log units) above what was measured, and the stated range ends above it.
By their numbers in this assay, from the lowest: compounds 4 and 2 (each within the scatter of the next); then compounds 1 and 3 (each within the scatter of the next).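

In this assay, a 1.4-fold lower number from compound 2 to compound 4 (0.14 log units; within the scatter), so phenyl in place of hydrogen on a saturated chain carbon, two bonds along the chain from an aromatic carbon, leaves the number within the scatter of compound 2. This differs from the earlier addition on this substituent position, a 5.6-fold higher number from compound 2 to compound 3 (0.75 log units; beyond the scatter), and shows that a large group entering here does not by itself bring a rise beyond the scatter: compound 3 shows such a rise and compound 4 does not, so the amount of added carbon alone does not set the read-out across these compounds. No measurement at hand bears on why the two additions part in this way.

Going by these compounds, it remains open whether this result is particular to the plain phenyl or extends to the same position more widely. A longer chain carrying the phenyl, or an amine or a carboxylic acid on the phenyl ring, would test whether the number stays within the scatter of compound 2 or moves away from it.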